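Methoxy Addition and Cytotoxicity in Two Matched Pairs

The compounds below may be only part of what the source reports. "The series", "measured", "known", "first", "only" and "open" are said of these compounds alone.

Three compounds from this study have been run in an ADME assay on MDBK cells (Bos taurus) for cytotoxicity, read by MTT assay, with a stated time of 96 h; on this read-out higher numbers stand for lower toxicity in this test and lower numbers for higher toxicity in this test. Compound 1 `COc1ccc(-c2nc3cc(C(C)O)ccc3[nH]2)cc1` and compound 2 `COc1ccc(-c2nc3cc(C(C)O)ccc3[nH]2)c(OC)c1` share one core, and compound 3 `COc1ccc(-c2nc3cc(C(C)=O)ccc3n2C2CCCCC2)cc1` has a core that is built differently; how the two cores differ is not broken down here. In this assay compound 1 reaches only the limit of the test, at > 100000 nM. In this assay compound 2 likewise reaches only the limit, at > 100000 nM. In this assay compound 3 also sits at the limit, at > 100000 nM. The change from compound 1 to compound 2 is methoxy in place of hydrogen on an aromatic carbon, and the step it made in this assay, a step that the two limits leave unreadable from compound 1 to compound 2, cannot be read because of the limit of > 100000 nM in this assay, at which 3 of the 3 values shown sit.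

Compound 4 `COc1ccc(-c2nc3cc(C(C)=O)ccc3n2C2CCCCC2)c(OC)c1` has not yet been measured in this assay. Going by the values given here, it is made from compound 3 by methoxy in place of hydrogen on an aromatic carbon, the same kind of change as the one from compound 1 to compound 2, with the surrounding place described in the same words. Given that compound 3 gives > 100000 nM in this assay, and that the earlier pair gave no readable step, compound 4 is expected to sit at or past the limit as well, an expected step that the limit leaves unreadable from compound 3 to compound 4. The estimate for compound 4 in this assay is 200000 nM, with an expected range from 80000 nM to 500000 nM, and the measurement itself is awaited.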

Compound 4, half-maximal cytotoxic concentration: 21000 nM
Estimate against measurement, compound 4: 9.5-fold (0.98 log units) above; measured number outside the range, below it.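

In this assay, methoxy in place of hydrogen on an aromatic carbon gives an at least 4.7-fold lower number from compound 3 to compound 4 (0.67 log units; beyond the scatter), so on the core of compound 3 the change brings a readable shift towards higher toxicity in this test. The same change from compound 1 to compound 2 leaves no readable step, and the step on the core of compound 3 is known only as a minimum, so the two cores can be called neither alike nor different in their response, because the values stop at one limit: the limit of > 100000 nM in this assay, at which 3 of the 4 values shown sit. This single readable pair shows that the change can bring a compound off the limit on one core, but it sets no rule for carrying the change across the series.

The compounds shown leave open which part of the difference between the two cores goes with the readable step, as no pair here separates the carbonyl from the alcohol or the cyclohexyl group from the ring hydrogen. Going by these compounds, it also stays open whether an ethoxy group or an amine in the same place would move the number as methoxy does on the core of compound 3.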